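The source may hold more compounds than are shown below. What is called first, only, known or untested is meant among the compounds shown, and "the series" means these compounds.

Compound 2 `COc1ccc(S(=O)(=O)N2CCc3cccc(-c4cccnc4)c32)cc1` gives 68.5 nM in a functional assay on MKN-45 cells (Homo sapiens) for inhibition, with a stated time of 72 h (a higher number here means a weaker inhibitor, a lower number a stronger inhibitor), the highest number among the three measured compounds. Compound 1 `COc1ccc(S(=O)(=O)N2CCc3cccc(-c4ccc([N+](=O)[O-])cc4)c32)cc1` gives 34 nM, and the step of a 2.0-fold higher number from compound 1 to compound 2 (0.30 log units; within the scatter) lies within the scatter; compound 3 `COc1ccc(S(=O)(=O)N2CCc3cccc(-c4ccc(C#N)cc4)c32)cc1` gives 17.2 nM, and the step of a 4.0-fold lower number from compound 2 to compound 3 (0.60 log units; beyond the scatter) lies beyond it. Compound 4 `COc1ccc(S(=O)(=O)N2CCc3cccc(-c4ccccc4)c32)cc1` differs from compound 2 by phenyl in place of pyridin-3-yl on an aromatic carbon. Going by the values given here, no measured step makes exactly this change; the nearest is a 4.0-fold lower number from compound 2 to compound 3 (0.60 log units; beyond the scatter), where 4-cyanophenyl replaces pyridin-3-yl, while a 2.0-fold lower number from compound 1 to compound 3 (0.30 log units; within the scatter) shows that the two phenyl-bearing compounds sit within the scatter of each other. Compound 4 is therefore expected to give a number at or somewhat below that of compound 2, a step of a 1.7-fold lower number from compound 2 to compound 4 (0.23 log units; within the scatter). Compound 4 is estimated at 40 nM, with a range from 15 nM to 110 nM.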

Compound 4, half-maximal inhibitory concentration: 117 nM
Estimate against measurement, compound 4: 2.9-fold (0.47 log units) below; the measured number lies above the stated range.
By their numbers in this assay, from the lowest: compounds 3, 1, 2 and 4 (each within the scatter of the next, the first and the last beyond it).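

In this assay, the step of a 1.7-fold higher number from compound 2 to compound 4 (0.23 log units; within the scatter) shows that exchanging pyridin-3-yl for phenyl at this position makes no difference that can be told from the scatter. Compound 4 also gives the unsubstituted reference for the phenyl series: the steps of a 6.8-fold higher number from compound 3 to compound 4 (0.83 log units; beyond the scatter) and a 3.4-fold higher number from compound 1 to compound 4 (0.54 log units; beyond the scatter) both lie beyond the scatter, so in these pairs the cyano and nitro groups go with lower numbers than hydrogen. No evidence is available that bears on this result. The compounds shown leave open how an amine or a carboxylic acid in place of cyano on the phenyl ring would compare with compound 3.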